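A Shorter Chain on Two Related Growth Inhibitors

The source may report more compounds than this note shows. Statements on the series, on what has been measured and on what is new or still open speak of the compounds shown alone.

compound 1 `CCCOC(=O)/C=C/c1ccc(C(C)C)cc1`: 5%
compound 2 `CCCCCCCCCCNC(=O)/C=C/c1ccccc1`: 15%
compound 3 `COC(=O)/C=C/c1ccc(C(C)C)cc1`: 21%

Three compounds were measured in a functional assay on the whole organism for inhibition, with Brassica rapa subsp. chinensis as the target, with a stated time of 3 days, tested at 100 ppm; a higher number here means more inhibition of growth at the concentration tested, a lower number less inhibition of growth. Compound 1 and compound 3 differ in one place: hydrogen in place of ethyl on a saturated chain carbon bound to an oxygen next to a carbonyl group. This change gave a number 16 percentage points higher from compound 1 to compound 3 (beyond the scatter). Compound 2 carries a different core; the difference between the core of compound 1 and the core of compound 2 is not broken down here. Compound 2 sits close to compound 3, within the scatter, and also within the scatter of compound 1.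

Compound 4 `CCCCCCCCNC(=O)/C=C/c1ccccc1` is not yet measured. It differs from compound 2 by hydrogen in place of ethyl on a saturated chain carbon, eight bonds along the chain from an amide-type nitrogen. This is the same kind of change as that from compound 1 to compound 3, but the place is not the same: there the carbon was bound to an oxygen next to a carbonyl group, here it lies eight bonds along the chain from an amide-type nitrogen.

Among the compounds with values here, the step is expected to be a number 5 percentage points higher from compound 2 to compound 4 (within the scatter), smaller than the one measured because a number 16 percentage points higher from compound 1 to compound 3 (beyond the scatter) was made at a place bound to the oxygen next to the carbonyl group rather than far along a chain. Compound 4 is therefore estimated at 20%, between 5% and 40%.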

Compound 4, percent growth inhibition at one concentration: 42%
Compound 4: middle estimate off by 22 percentage points, on the low side; the measured number lies above the stated range.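

In this assay, putting hydrogen in place of ethyl gave a higher number on both cores, and the new step, a number 27 percentage points higher from compound 2 to compound 4 (beyond the scatter), points the same way as the earlier one, a number 16 percentage points higher from compound 1 to compound 3 (beyond the scatter). Set side by side, the two steps do not differ beyond what repeated measurements allow: the same change on two cores in this assay, a number 16 percentage points higher (beyond the scatter) from compound 1 to compound 3 and a number 27 percentage points higher (beyond the scatter) from compound 2 to compound 4, 11 percentage points apart, within the scatter of two such steps. This shows that the change carried over from one core to the other in direction and, within the scatter, in size, but it rests on a single pair per core, made at two different places (on a carbon bound to an oxygen next to a carbonyl group, and eight bonds along the chain from an amide-type nitrogen), and it does not show why the number rises or that the step would hold on any further core.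

The compounds shown leave open how a hexyl or butyl chain on the amide nitrogen would read in this assay. They also leave open whether a carboxylic acid in place of the ester would follow the same course.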